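A few compounds are considered here, and "the series" means these few. Any claim that something is new, unique, unknown or untested is made for them only; others in the source may bear on it.

Compound 1 `C[C@@H]1CN(c2sc(C(F)(F)F)nc2-c2nc3cc(OCCO)ccc3[nH]2)CCN1C(=O)Cn1cnc2cccnc21` gives the lowest number of the two measured in a functional assay on CHO-K1 cells for antagonist activity at C-X-C chemokine receptor type 3 (Homo sapiens), read by FLIPR, with a stated time of 10 min, in the presence of a further agent that is not named here (a higher number here means a weaker inhibitor, a lower number a stronger inhibitor), at 2.1 nM. Compound 2 `Cc1nc(C)n(CC(=O)N2CCN(c3sc(C(F)(F)F)nc3-c3nc4ccccc4[nH]3)C[C@H]2C)n1` in this assay gives 3.2 nM, which lies within the scatter of compound 1, so the two are not separated. Compound 3 `C[C@@H]1CN(c2sc(C(F)(F)F)nc2-c2nc3cc(Cl)ccc3[nH]2)CCN1C(=O)Cn1cnc2cccnc21` is not yet measured; relative to compound 1 it carries chloro in place of 2-hydroxyethoxy on an aromatic carbon. Among the compounds with values here, no measured pair tracks this change, so the direction rests on expectation only. The step of a 1.7-fold higher number from compound 1 to compound 3 (0.22 log units; within the scatter) is expected to be small, a modest move toward a higher number at most. Compound 3 is expected to give 3.5 nM in this assay, within 1.2 nM to 10 nM.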

Compound 3, half-maximal inhibitory concentration: 2.8 nM
For compound 3 the middle estimate is 1.3-fold (0.10 log units) above the measured one; the measured number falls inside the stated range.
By their numbers in this assay, from the lowest: compounds 1, 3 and 2 (each within the scatter of the next).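

In this assay, chloro in place of 2-hydroxyethoxy gives a 1.3-fold higher number from compound 1 to compound 3 (0.12 log units; within the scatter), so compounds 1 and 3 are not separated. At this aromatic carbon, a single chlorine atom and a chain of 4 heavy atoms carrying a hydrogen-bond donor therefore read alike, at least on this core. No measurement at hand accounts for this result. On these data alone, what an amine, a carboxylic acid or a longer ether chain would give at this carbon remains open. So does whether the same exchange would read alike with the side chain of compound 2.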